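Carbamate to amide on the indole-bound nitrogen

The source may report more compounds than this note shows. Statements on the series, on what has been measured and on what is new or still open speak of the compounds shown alone.

Measured compounds:
compound 1, `COc1cc(C(=O)NS(=O)(=O)c2ccccc2)ccc1Cc1cn(C)c2ccc(NC(=O)OC3CCCC3)cc12`, 9.69 in an assay on isolated protein (Cavia porcellus) with cysteinyl leukotriene receptor (Homo sapiens) as the target; a lower number here means a less potent compound, a higher number a more potent compound, by a factor of ten per unit of this negative logarithm
compound 2, `COc1cc(C(=O)O)ccc1Cc1cn(C2CCCC2)c2ccc(NC(=O)OC3CCCC3)cc12`, 7.67 in this assay
compound 3, `COc1cc(C(=O)O)ccc1Cn1ccc2ccc(NC(=O)OC3CCCC3)cc21`, 7.8 in this assay

Compound 3 stands well below compound 1, the gap to compound 1 lying beyond the scatter of the method, while its value and that of compound 2 lie within the scatter of each other, so no order between compound 3 and compound 2 can be read from these two numbers. Going by the values given here, the three measured compounds differ in more than one place, so no single step between them is counted.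

Compound 4, `COc1cc(C(=O)O)ccc1Cn1ccc2ccc(NC(=O)CC3CCCC3)cc21`, carries the change cyclopentylmethyl in place of cyclopentyloxy on a carbonyl carbon, the carbamate of compound 3 thus becoming an amide. Among the compounds with values here, no measured pair shows this change, so the expectation rests only on the unchanged remainder of the structure. The step from compound 3 to compound 4 in this assay is expected at a number 0.30 log units lower from compound 3 to compound 4 (within the scatter), that is, no shift beyond the scatter or a modest loss. Compound 4 is therefore estimated at 7.5, with a range from 6.8 to 8.2.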

Compound 4, negative logarithm of the antagonist equilibrium constant: 7.68
Compound 4: middle estimate off by 0.18 log units, on the low side; the range from low to high includes it.
By their numbers in this assay, from the lowest: compounds 2, 4 and 3 (each within the scatter of the next); then compound 1.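

In this assay, going by these compounds alone, cyclopentylmethyl in place of cyclopentyloxy on a carbonyl carbon gives a number 0.12 log units lower from compound 3 to compound 4 (within the scatter), the first comparison that differs in one place only. In this single pair, the carbamate and the amide cannot be told apart, so the oxygen of cyclopentyloxy is not needed for a value in this range on the core of compound 3. Nothing available bears on why the two groups read alike.

From the compounds shown here alone, whether the same holds with an amine nitrogen in place of that oxygen, giving a urea, or with a longer chain such as cyclopentylethyl on the carbonyl carbon remains open. Also open, going by these compounds, is whether the amide reads like the carbamate on the core of compound 1, which carries the benzenesulfonyl amide.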